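The source may report more compounds than this note shows. Statements on the series, on what has been measured and on what is new or still open speak of the compounds shown alone.

Among the measured compounds shown here, compound 2 `CC(C(=O)NCc1ccc(C(F)(F)F)cc1)N1C(=O)CCC1=O` sits in the middle of the three compounds measured so far: in a functional assay on the whole organism (strain Albino Swiss CD1) with Mus musculus as the target, in the maximal electroshock model (a lower number here means that less compound is needed, a higher number that more compound is needed for the effect), compound 2 gives 80.1 mg/kg. Its closest neighbour is compound 1 `CC(C(=O)NCc1ccc(Cl)cc1)N1C(=O)CCC1=O`, which in this assay gives 91.8 mg/kg, and the change of trifluoromethyl in place of chloro on the aromatic carbon produced a 1.1-fold lower number from compound 1 to compound 2 (0.06 log units; within the scatter). Further off lies compound 3 `CCC(C(=O)NCc1ccc(C(F)(F)F)cc1)N1C(=O)CCC1=O`, which gives 69.4 mg/kg in this assay after methyl in place of hydrogen on the saturated chain carbon, a step of a 1.2-fold lower number from compound 2 to compound 3 (0.06 log units; within the scatter).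

Compound 4 `CC1CC(=O)N(C(C)C(=O)NCc2ccc(C(F)(F)F)cc2)C1=O` differs from compound 2 by methyl in place of hydrogen on a saturated ring carbon. For the measured compounds named here, no measured step adds a methyl to the ring itself, so the only step that bears on it is the one from compound 2 to compound 3, where a methyl was likewise added to a saturated carbon of the shared core and the dose moved by an amount that stays inside the scatter. On this basis no movement beyond the scatter is expected for compound 4 in this assay, the estimated step from compound 2 being a 1.1-fold lower number from compound 2 to compound 4 (0.03 log units; within the scatter). The dose for compound 4 is accordingly estimated at 75 mg/kg, with a range from 50 mg/kg to 115 mg/kg.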

Compound 4, dose for half-maximal effect: > 150 mg/kg
Compound 4 gave a limit, no number (the forecaster's own chance of this, stated with the estimate: 5%); at least 2.0-fold (0.30 log units) between middle value and limit.
By their numbers in this assay, from the lowest: compounds 3, 2 and 1 (each within the scatter of the next). At a limit, above all of these: compound 4.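

In this assay compound 4 gives no number, only a limit of the assay: the limit of > 150 mg/kg in this assay, at which 1 of the 4 values shown sits.
The methyl on the saturated ring carbon, two ring bonds from the ring nitrogen, is thus the first change shown whose result cannot be placed among the measured doses, whereas the earlier changes on the aromatic carbon and the chain carbon both ended in numbers within the scatter of each other. The change from 2,5-dioxopyrrolidin-1-yl to 3-methyl-2,5-dioxopyrrolidin-1-yl gives an at least 1.8-fold higher number from compound 2 to compound 4 (0.27 log units; that floor lies within the scatter) and so points towards more compound being needed, although that floor alone does not establish a move beyond the scatter, and the chain-carbon methyl gives no guide to this ring position.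

Going by these compounds, the actual dose of compound 4 stays unknown, and so does how far it lies from compound 2. Also open, on these data alone, is whether an ethyl or a hydroxyl on the same ring carbon would give a number in this assay, and whether the ring methyl would behave the same way on the core of compound 3.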